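From Pyridin-4-yl Carbonyl to Tert-Butyl Carbamoyl

This account rests on a few compounds, and the source may have more. Where it says the series, first, only, none or still open, it means among the compounds named here.

Compound 1: `O=C(CN1CCCC1)N1CCC(NS(=O)(=O)c2cc(S(=O)(=O)c3ccccc3)ccc2C(F)(F)F)CC1` gives 190 nM
Compound 2: `O=C([C@@H]1CCCN1C(=O)c1ccncc1)N1CCC(NS(=O)(=O)c2cc(S(=O)(=O)c3ccccc3)ccc2C(F)(F)F)CC1` gives 350 nM

Of the compounds shown here, two have been measured in a functional assay on U2OS cells for antagonist activity at proto-oncogene Wnt-3 (Homo sapiens), read by a luciferase reporter, with a stated time of 18 h; a lower number here means that less compound is needed, a higher number that more compound is needed for the effect. Compound 1 gives 190 nM there. Compound 2 gives 350 nM, which is the higher of the two numbers, but the gap to compound 1 lies within the usual scatter, so the two cannot be told apart on these data.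

Compound 3, `CC(C)(C)NC(=O)N1CCC[C@H]1C(=O)N1CCC(NS(=O)(=O)c2cc(S(=O)(=O)c3ccccc3)ccc2C(F)(F)F)CC1`, has not yet been measured. It differs from compound 2 in one place: (tert-butyl)amino in place of pyridin-4-yl on a carbonyl carbon. The shared core, from the sulfonamide through the piperidine to the ring-bound amide nitrogen, is unchanged.

Among the compounds with values here, no pair of measured compounds differing in a single place is available, so the effect of this change cannot be read off a measured step. Compound 1 and compound 2 differ considerably at this same end of the molecule and still land close together, which suggests this end tolerates variation. The step of a 1.2-fold lower number from compound 2 to compound 3 (0.07 log units; within the scatter) is therefore expected to stay within the scatter. Compound 3 is estimated to give 300 nM, with a range from 100 nM to 1000 nM.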

Compound 3, half-maximal effective concentration: 30 nM
Compound 3: the middle estimate sits 10-fold (1.00 log units) above what was measured, and the stated range ends above it.
By their numbers in this assay, from the lowest: compound 3; then compounds 1 and 2 (each within the scatter of the next).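

In this assay, putting (tert-butyl)amino in place of pyridin-4-yl on a carbonyl carbon gives a 12-fold lower number from compound 2 to compound 3 (1.07 log units; beyond the scatter), so this end of the molecule clearly does respond to what is attached there, which the close values of the two earlier compounds gave no sign of. The second available step, 1-((tert-butyl)carbamoyl)pyrrolidin-2-yl in place of (pyrrolidin-1-yl)methyl on a carbonyl carbon, gives a 6.3-fold lower number from compound 1 to compound 3 (0.80 log units; beyond the scatter), and with both steps beyond the scatter, compound 3 has the lowest number of the three. Nothing measured here gives a reason for this gain.

The compounds shown leave open which part of the change matters: in one step an aromatic ring leaves and a hydrogen-bond donor enters, and no compound here separates the two. Going by these compounds, how a dimethylamino group, which carries no amide hydrogen, or a cyclohexyl group on the same carbonyl carbon would compare with (tert-butyl)amino remains unknown, so the role of the amide hydrogen and of the tert-butyl group cannot yet be told apart.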